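From Fluoro to Methyl on the Benzyl Group

The compounds below may be only part of what the source reports. "The series", "measured", "known", "first", "only" and "open" are said of these compounds alone.

In a functional assay on A2780 cells (Homo sapiens) for antiproliferative activity, read by resazurin assay, with a stated time of 72 h (on this read-out lower numbers stand for stronger inhibition and higher numbers for weaker inhibition), compound 1 (`Cc1ccccc1Cc1n[nH]c2cc(O)c(C(=O)N(C)Cc3ccccc3)cc12`) stands as "not determined" (no result reported) and offers no comparison. Within the data shown here, compound 2 (`CN(Cc1ccccc1)C(=O)c1cc2c(Cc3cccc(F)c3)n[nH]c2cc1O`) gives 1700 nM as the only number available, so it cannot yet be ranked against any other compound. Compound 3 (`Cc1cccc(Cc2n[nH]c3cc(O)c(C(=O)N(C)Cc4ccccc4)cc23)c1`) has not been measured. It carries methyl in place of fluoro on an aromatic carbon, meta to a large group (methyl in place of fluoro on an aromatic carbon), which turns 3-fluorobenzyl into 3-methylbenzyl. Among the measured compounds shown here, no measured step shows what such a swap does, so no step beyond the usual scatter is expected in this assay, in either direction. The expectation rests on compound 2 at 1700 nM alone, and the range is kept wide. The expected change a 1.1-fold lower number from compound 2 to compound 3 (0.05 log units; within the scatter) is estimated to be small. Compound 3 is estimated at 1500 nM with 600 nM to 4000 nM as the expected range.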

Compound 3, half-maximal inhibitory concentration: 490 nM
Compound 3: the middle estimate sits 3.1-fold (0.49 log units) above what was measured; measured number below the stated range.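

In this assay, replacing fluoro with methyl on the aromatic carbon of the benzyl group gives a 3.5-fold lower number from compound 2 to compound 3 (0.54 log units; beyond the scatter). Among these compounds, this is the first sign that the assay responds to this position: exchanging one heavy atom for another, with no change in ring, hydrogen-bond donors, hydrogen-bond acceptors or net charge, moves the number by more than the usual scatter. Nothing given here accounts for why the methyl version gives the lower number.

Among the compounds shown here, compound 1 has no reported result, so no step involving it can be read. As far as these compounds go, whether an unsubstituted benzyl group, a chlorine, a methoxy group or an amine on this ring would give a lower or a higher number than methyl remains open.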